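Stepping from compound 3 to compound 4

This account rests on a few compounds, and the source may have more. Where it says the series, first, only, none or still open, it means among the compounds named here.

Of the compounds shown here, three with a shared core have been measured in a functional assay on A549 cells (Homo sapiens) for antiproliferative activity, read by MTT assay, with a stated time of 48 h; on this read-out lower numbers stand for stronger inhibition and higher numbers for weaker inhibition. Compound 1 (`COc1ccc(/C=C/c2cc(OC)cc(OC)c2/C=C/C(=O)c2cccc(Br)c2)cc1`) gives 8.1 ug/mL, compound 2 (`COc1ccc(/C=C/c2cc(OC)cc(OC)c2/C=C/C(=O)c2cccc(Cl)c2)cc1`) gives 5.6 ug/mL, and compound 3 (`COc1ccc(/C=C/c2cc(OC)cc(OC)c2/C=C/C(=O)c2ccc(C(F)(F)F)cc2)cc1`) gives 7.8 ug/mL. Compound 3 therefore stands within the scatter of both other compounds.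

The change to compound 4 (`COc1ccc(/C=C/c2cc(OC)cc(OC)c2/C=C/C(=O)c2ccccc2C)cc1`) puts 2-methylphenyl in place of 4-(trifluoromethyl)phenyl on a carbonyl carbon.

Two measured steps exchange the group at this same place: a 1.0-fold lower number from compound 1 to compound 3 (0.02 log units; within the scatter) and a 1.4-fold higher number from compound 2 to compound 3 (0.14 log units; within the scatter). A third, with chloro in place of bromo on an aromatic carbon, is a 1.4-fold lower number from compound 1 to compound 2 (0.16 log units; within the scatter). All three lie within the scatter. Within the data shown here, no measured compound carries a 2-methylphenyl group, so the entering group itself remains untested.

No step beyond the scatter is expected in this assay. The estimated step is a 1.1-fold lower number from compound 3 to compound 4 (0.05 log units; within the scatter). For compound 4 the expected value is 7 ug/mL, with an estimated range from 3.5 ug/mL to 14 ug/mL.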

Compound 4, half-maximal inhibitory concentration: 5.9 ug/mL
For compound 4 the middle estimate is 1.2-fold (0.07 log units) above the measured one, within the range that was stated.
By their numbers in this assay, from the lowest: compounds 2, 4, 3 and 1 (each within the scatter of the next).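

In this assay the 2-methylphenyl group on the carbonyl carbon gives a 1.3-fold lower number from compound 3 to compound 4 (0.12 log units; within the scatter) and also a 1.1-fold higher number from compound 2 to compound 4 (0.02 log units; within the scatter) and a 1.4-fold lower number from compound 1 to compound 4 (0.14 log units; within the scatter) at this same place. The tolerated set at this position therefore now extends to an aryl group carrying only carbon, with no halogen atom, and all four aryl groups shown remain within the scatter of one another. No measurement on hand offers an explanation for this flat picture.

The compounds shown leave open whether an amine or a carboxylic acid on this aromatic ring, or a longer chain in place of the methyl, would give a step beyond the scatter. They also leave open how a plain phenyl group on the carbonyl carbon would compare.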